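A Methoxy Step Tested on Two Cores

The source may report more compounds than this note shows. Statements on the series, on what has been measured and on what is new or still open speak of the compounds shown alone.

Compound 1 `COc1cc2occ(-c3csc4ccccc34)c(=O)c2c(OC)c1OC`: 820 nM
Compound 2 `COc1cc2occ(-c3csc4ccccc34)c(=O)c2cc1OC`: > 10000 nM
Compound 3 `COc1ccc(C(=O)/C=C/c2csc3ccccc23)c(O)c1`: 5600 nM

In a functional assay on KB cells (Homo sapiens) for antiproliferative activity, read by sulforhodamine B assay, with a stated time of 72 h (on this read-out higher numbers stand for weaker inhibition and lower numbers for stronger inhibition), compound 1 gives 820 nM. For compound 2 the value > 10000 nM is a limit of this assay rather than a number (the limit of > 10000 nM in this assay, at which 1 of the 3 values shown sits). Compound 3 gives 5600 nM in this assay. Between compound 2 and compound 1 the change is methoxy in place of hydrogen on an aromatic carbon, and it brought an at least 12-fold lower number from compound 2 to compound 1 (1.08 log units; beyond the scatter). Compound 4, `COc1cc(O)c(C(=O)/C=C/c2csc3ccccc23)cc1OC`, is not yet measured; it differs from compound 3 by methoxy in place of hydrogen on an aromatic carbon. The difference between the two cores is not broken down here. The two changes are the same kind of change, but the place differs: in compound 1 the methoxy sits on a ring that is part of a fused or bridged system of two rings, ortho to a fused ring and meta to a methoxy group, whereas in compound 4 it sits meta to a large group and para to a hydroxy group. Because the same kind of change produced an at least 12-fold lower number from compound 2 to compound 1 (1.08 log units; beyond the scatter), a gain is expected here too, though a smaller one on a different core. Compound 4 is estimated at 2500 nM, a step of a 2.2-fold lower number from compound 3 to compound 4 (0.35 log units; beyond the scatter), within 600 nM to 8000 nM.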

Compound 4, half-maximal inhibitory concentration: 520 nM
Estimate against measurement, compound 4: 4.8-fold (0.68 log units) above; the whole stated range lies above it.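

In this assay, methoxy in place of hydrogen on an aromatic carbon brought an 11-fold lower number from compound 3 to compound 4 (1.03 log units; beyond the scatter), so the change lowered the number on the second core as it had on the core of compound 1, although the methoxy sits in a different place on each and two cores say nothing about any others in the series. Set side by side, the two steps read as follows: the same change on two cores in this assay, an at least 12-fold lower number (1.08 log units; beyond the scatter) from compound 2 to compound 1 and an 11-fold lower number (1.03 log units; beyond the scatter) from compound 3 to compound 4; the limit leaves it open whether they differ

For compound 2 the value > 10000 nM is a limit of the assay and not a number.

The compounds shown leave open whether the gain belongs to methoxy in particular or would also come with an ethoxy group, a longer chain or an amine on the same aromatic carbon. They also leave open whether the same steps would appear in any assay other than this assay.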